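Swapping one halogen on the lower-number azide compound

This account rests on a few compounds, and the source may have more. Where it says the series, first, only, none or still open, it means among the compounds named here.

- compound 1 `CC(=O)O[C@@H]1[C@H](OC(C)=O)[C@@H](CS(C)(=O)=O)O[C@H]1n1cnc2c(N)nc(Cl)nc21` gives 114000 nM
- compound 2 `CC(=O)O[C@@H]1[C@H](OC(C)=O)[C@@H](CN=[N+]=[N-])O[C@H]1n1cnc2c(N)nc(F)nc21` gives 18000 nM

In an ADME assay on L6 cells (Rattus norvegicus) for inhibition, read by resazurin assay, with a stated time of 72 h (on this read-out higher numbers stand for weaker inhibition and lower numbers for stronger inhibition), compound 2 gives the lower of the two numbers (18000 nM). The gap to compound 1 (114000 nM) lies beyond the usual scatter, so compound 2 is clearly the stronger inhibitor of this pair.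

The next molecule, compound 3 (`CC(=O)O[C@@H]1[C@H](OC(C)=O)[C@@H](CN=[N+]=[N-])O[C@H]1n1cnc2c(N)nc(Cl)nc21`), keeps everything in compound 2 except one group: chloro in place of fluoro on an aromatic carbon. That carbon sits between two ring nitrogen atoms in the shared core.

Among the compounds with values here, no measured pair shows this swap on its own, so the data offer no direct guide to its size or direction. The expectation therefore starts from compound 2 (18000 nM) and stays cautious: a modest move towards a higher number in this assay, possibly not much beyond the scatter. The estimated step is a 1.7-fold higher number from compound 2 to compound 3 (0.22 log units; within the scatter) in this reading. For compound 3 the expected value is 30000 nM (estimated range 10000 nM to 90000 nM).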

Compound 3, half-maximal inhibitory concentration: 141000 nM
Beside the measured number, compound 3's estimate is 4.7-fold (0.67 log units) below it; measured number above the stated range.
By their numbers in this assay, from the lowest: compound 2; then compounds 1 and 3 (each within the scatter of the next).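

In this assay, within the data shown here, the swap of chloro for fluoro on the aromatic carbon between two ring nitrogen atoms gives a 7.8-fold higher number from compound 2 to compound 3 (0.89 log units; beyond the scatter) and so lies beyond the scatter: this single-atom change in the shared core clearly weakens inhibition when an azido group sits on the side chain, something no earlier pair could show on its own. With chloro held constant on the core, azido in place of methylsulfonyl on the saturated chain carbon gives a 1.2-fold higher number from compound 1 to compound 3 (0.09 log units; within the scatter) and stays within the scatter, so among these three compounds the fluoro compound alone stands apart, while the two chloro compounds cannot be told apart. The data offered here give no measured explanation for the size of the halogen step.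

From the compounds shown here alone, whether fluoro would stand apart in the same way with methylsulfonyl on the side chain remains open. Also open, going by these compounds, is how a bromo group or an amine on that same aromatic carbon would read, so the three compounds show a single halogen swap rather than a trend across this position.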